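Methyl Next to the Ring Nitrogen: A Pyridine Amidrazone Thiosemicarbazide

The source may report more compounds than this note shows. Statements on the series, on what has been measured and on what is new or still open speak of the compounds shown alone.

Measured compounds:
- compound 1 `N/C(=N\NC(=S)N1CCCCCC1)c1ccccn1`: 3000 nM
- compound 2 `N/C(=N\NC(=S)N1CCCC1)c1ccc(F)cn1`: 1000 nM
- compound 3 `Cc1ccnc(/C(N)=N/NC(=S)N2CCCCCC2)c1`: 8000 nM

In a functional assay on A-431 cells (Homo sapiens) for cytotoxicity, read by MTT assay, with a stated time of 72 h (a higher number here means a weaker inhibitor, a lower number a stronger inhibitor), compound 1 gives 3000 nM and stands second highest of the three numbers. Its nearest neighbour is compound 3, and the step of a 2.7-fold higher number from compound 1 to compound 3 (0.43 log units; beyond the scatter) is a modest one, beyond the scatter. Compound 2, with a different ring on the thiourea and a fluorine on the aromatic ring, gives 1000 nM, the lowest number of the three.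

Compound 4 `Cc1cccc(/C(N)=N/NC(=S)N2CCCCCC2)n1` differs from compound 1 in one place: methyl in place of hydrogen on an aromatic carbon. For the measured compounds named here, the only measured step that bears on it is the one from compound 1 to compound 3, where a methyl on a different aromatic carbon of the same ring gave a modest increase in the number. Nothing measured tells how a methyl placed next to the ring nitrogen behaves, so the expectation rests on that single step alone.

Compound 4 is therefore expected to show a small increase in this assay, about a 1.7-fold higher number from compound 1 to compound 4 (0.22 log units; within the scatter). The estimate for compound 4 is 5000 nM, with a range from 2000 nM to 15000 nM.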

Compound 4, half-maximal inhibitory concentration: 14700 nM
Compound 4: middle estimate off by 2.9-fold (0.47 log units), on the low side; low and high end bracket the measured number.
By their numbers in this assay, from the lowest: compound 2; then compound 1; then compounds 3 and 4 (each within the scatter of the next).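

In this assay, methyl in place of hydrogen on the aromatic carbon next to the ring nitrogen gives a 4.9-fold higher number from compound 1 to compound 4 (0.69 log units; beyond the scatter) and so makes for a weaker inhibitor at this position as well. Compound 3 gives 8000 nM and compound 4 gives 14700 nM, and these two values lie within the scatter of each other, so the two places for the methyl on this ring cannot be told apart here. Nothing among the data shown explains the change at this position.

As far as these compounds go, it remains open whether a chlorine, a methoxy group or an amine at this place would also raise the number, or whether a longer chain would raise it further. From the compounds shown here alone, it is equally open whether the methyl would have the same effect on a core with another ring on the thiourea.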